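Swapping the Side-Chain Heterocycle on Compound 2

The source may hold more compounds than are shown below. What is called first, only, known or untested is meant among the compounds shown, and "the series" means these compounds.

Among the measured compounds shown here, compound 2 `CCO/C(O)=C1\C(COCCn2cc(C(N)=O)nn2)=NC(C)=C(C(=O)OC)C1c1ccccc1Cl` holds the higher of the two numbers measured so far: in a functional assay (aorta) with Rattus norvegicus as the target (on this read-out lower numbers stand for stronger inhibition and higher numbers for weaker inhibition), compound 2 gives 20 nM, whereas compound 1 `CCO/C(O)=C1\C(COCCn2cc(C(N)=O)nn2)=NC(C)=C(C(=O)OC)C1c1cccc(Cl)c1Cl` gives 3.16 nM. For the measured compounds named here, the only measured step is a 6.3-fold higher number from compound 1 to compound 2 (0.80 log units; beyond the scatter). That step concerns the aryl ring, not the chain. Compound 3 `CCO/C(O)=C1\C(COCCn2c(N)cnc2O)=NC(C)=C(C(=O)OC)C1c1ccccc1Cl` keeps the aryl ring of compound 2 unchanged and instead alters the heterocycle on the chain: 5-amino-2-hydroxy-1H-imidazol-1-yl in place of 4-carbamoyl-1H-1,2,3-triazol-1-yl on a saturated chain carbon, two bonds along the chain from an oxygen on a saturated carbon. Going by the values given here, no measured step touches this part of the shared core, so nothing among the numbers speaks directly to the change; the one step that exists, a 6.3-fold higher number from compound 1 to compound 2 (0.80 log units; beyond the scatter), is modest and sits elsewhere. The analyst therefore expects no step beyond the usual scatter from compound 2 to compound 3, while allowing a wide margin in either direction for an untested exchange of this kind. For compound 3 the estimate in this assay is 20 nM, expected to fall between 5 nM and 80 nM. This estimate corresponds to an expected step of no change at the digits printed from compound 2 to compound 3 (within the scatter).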

Compound 3, half-maximal inhibitory concentration: 158 nM
Beside the measured number, compound 3's estimate is 7.9-fold (0.90 log units) below it, and the stated range ends below it.
By their numbers in this assay, from the lowest: compound 1; then compound 2; then compound 3.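

The heterocycle at the end of the chain turns out to be a place where the read-out responds: in this assay, the exchange of 4-carbamoyl-1H-1,2,3-triazol-1-yl for 5-amino-2-hydroxy-1H-imidazol-1-yl gives a 7.9-fold higher number from compound 2 to compound 3 (0.90 log units; beyond the scatter). The earlier compounds shown here showed a response only on the aryl ring, with a 6.3-fold higher number from compound 1 to compound 2 (0.80 log units; beyond the scatter), and both steps are modest, so with the aryl ring held constant, this change on the chain alone moves the number beyond the scatter, toward weaker inhibition. No measurement offered here bears on what lies behind this loss, and the step itself gives no reason for it.

Because this exchange replaces the whole heterocycle in one move, the compounds shown do not separate the effect of the imidazole ring from that of its amino or hydroxy group, and they leave open how a carboxylic acid in place of the carboxamide on the triazole, a simple amine at the chain end, or a longer chain would read. They also leave open whether the second chloro that separates compound 1 from compound 2 would give a similar step when the chain carries the imidazole.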